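Nitro for cyano on two cores: the series so far

This account rests on a few compounds, and the source may have more. Where it says the series, first, only, none or still open, it means among the compounds named here.

All values come from a functional assay on DU-145 cells (Homo sapiens) for antiproliferative activity, read by propidium iodide staining, with a stated time of 96 h; on this read-out higher numbers stand for weaker inhibition and lower numbers for stronger inhibition.
compound 1, `CC(O)(CSc1cccc(S(F)(F)(F)(F)F)c1)C(=O)Nc1ccc(C#N)cc1C(F)(F)F`: 37400 nM
compound 2, `CC(O)(CSc1cccc(S(F)(F)(F)(F)F)c1)C(=O)Nc1ccc([N+](=O)[O-])cc1C(F)(F)F`: 18900 nM
compound 3, `CC(O)(CS(=O)(=O)c1ccc(S(F)(F)(F)(F)F)cc1)C(=O)Nc1ccc(C#N)cc1C(F)(F)F`: 25600 nM

Compound 2 differs from compound 1 by nitro in place of cyano on an aromatic carbon. This change gave a 2.0-fold lower number from compound 1 to compound 2 (0.30 log units; within the scatter) in this assay. Compound 3 carries a different core; how the core of compound 3 differs from the core of compound 1 is not broken down here. The value of compound 3 lies within the scatter of those of compound 1 and compound 2, so no order among the three can be read from this assay.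

Compound 4, `CC(O)(CS(=O)(=O)c1ccc(S(F)(F)(F)(F)F)cc1)C(=O)Nc1ccc([N+](=O)[O-])cc1C(F)(F)F`, has not yet been measured in this assay. It differs from compound 3 by nitro in place of cyano on an aromatic carbon, the same change, at the same place, as that from compound 1 to compound 2. The expected step on the core of compound 3 is a 2.0-fold lower number from compound 3 to compound 4 (0.29 log units; within the scatter), because the same change gave a 2.0-fold lower number from compound 1 to compound 2 (0.30 log units; within the scatter) on the other core, and nothing else in the series bears on it. Compound 4 is therefore estimated at 13000 nM, with a likely range from 6000 nM to 28000 nM.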

Compound 4, half-maximal inhibitory concentration: 17700 nM
The estimate for compound 4 lay 1.4-fold (0.13 log units) below the measured number; the range from low to high includes it.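

Nitro in place of cyano on the core of compound 3 gave, in this assay, a 1.4-fold lower number from compound 3 to compound 4 (0.16 log units; within the scatter). Set beside the earlier step on the other core, this step shows no difference between the two cores: the same change on two cores in this assay, a 2.0-fold lower number (0.30 log units; within the scatter) from compound 1 to compound 2 and a 1.4-fold lower number (0.16 log units; within the scatter) from compound 3 to compound 4, 1.4-fold (0.14 log units) apart, within the scatter of two such steps

So the change carries from one core to the other without any measurable dependence on the core, but this does not show that nitro and cyano differ in this read-out, since each step on its own lies within the scatter, and two cores say nothing about how the change would behave on any further core.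

Going by these compounds, all four compounds carry only nitrile or nitro at this place, so the effect of an amine or a carboxylic acid there remains open. The trifluoromethyl group is also constant throughout, which leaves open what a chlorine atom in its place would do on either core.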